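Shortening the ether side chain of compound 2

This account rests on a few compounds, and the source may have more. Where it says the series, first, only, none or still open, it means among the compounds named here.

Measured so far in a functional assay on HT-29 cells (Homo sapiens) for antiproliferative activity, read by MTT assay, with a stated time of 72 h (on this read-out lower numbers stand for stronger inhibition and higher numbers for weaker inhibition), are
Compound 1 `CC(O)COc1ccc2c(Oc3ccc(Nc4nccc5[nH]cc(-c6ccc(F)cc6)c(=O)c45)cc3F)ccnc2c1` at 3900 nM
Compound 2 `COC(C)(C)COc1ccc2c(Oc3ccc(Nc4nccc5[nH]cc(-c6ccc(F)cc6)c(=O)c45)cc3F)ccnc2c1` at 4800 nM

Compound 2 gives 4800 nM and lies within the scatter of compound 1, so these two numbers cannot be ranked. Compound 3 `COCCOc1ccc2c(Oc3ccc(Nc4nccc5[nH]cc(-c6ccc(F)cc6)c(=O)c45)cc3F)ccnc2c1` has not yet been measured. Its difference from compound 2 is methoxymethyl in place of 1-methoxy-1-methylethyl on a saturated chain carbon bound to an oxygen on an aromatic ring and amounts to methoxymethyl in place of 1-methoxy-1-methylethyl on a saturated chain carbon bound to an oxygen on an aromatic ring. Read one bond further out, this is 2-methoxy-2-methylpropoxy to 2-methoxyethoxy.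

For the measured compounds named here, one measured step bears on this change, made at the same place. That step is a 1.2-fold higher number from compound 1 to compound 2 (0.09 log units; within the scatter) and it stayed within the scatter. On this single step, no shift beyond the scatter is expected in this assay in either direction. The expected step is a 1.1-fold lower number from compound 2 to compound 3 (0.06 log units; within the scatter) and it is estimated to remain within the scatter. For compound 3 the estimated value is 4200 nM with an expected range from 1900 nM to 9000 nM on this read-out.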

Compound 3, half-maximal inhibitory concentration: 6500 nM
Compound 3: the middle estimate sits 1.5-fold (0.19 log units) below what was measured; low and high end bracket the measured number.
By their numbers in this assay, from the lowest: compounds 1, 2 and 3 (each within the scatter of the next).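

In this assay, the change from 2-methoxy-2-methylpropoxy to 2-methoxyethoxy gives a 1.4-fold higher number from compound 2 to compound 3 (0.13 log units; within the scatter), so removing the branching from the methoxy-bearing chain produces no readable difference. The replacement of 1-hydroxyethyl by methoxymethyl gives a 1.7-fold higher number from compound 1 to compound 3 (0.22 log units; within the scatter), which shows that this pair also cannot be separated, and thus no two of the three side chains on the shared core can be ranked at this position. No supporting evidence is available that bears on this result.

The three compounds leave open whether any change at this position can move the antiproliferative read-out beyond the scatter, since each side chain shown is a short chain carrying a hydroxyl or methoxy group. How a terminal dimethylamino group, a carboxylic acid or a longer chain would read at this place remains an open question, as does whether the same lack of separation would hold for such groups on this core.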